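A few compounds are considered here, and "the series" means these few. Any claim that something is new, unique, unknown or untested is made for them only; others in the source may bear on it.

Measured compounds in a functional assay on MT4 cells (Homo sapiens); a lower number here means that less compound is tolerated, a higher number that more compound is tolerated:
compound 1 `Cc1cn([C@@H]2O[C@H](CO[Si](C)(C)C(C)(C)C)[C@@]3(OS(=O)(=O)C=C3NCCC(=O)OCc3ccccc3)[C@H]2O[Si](C)(C)C(C)(C)C)c(=O)n(C)c1=O`: > 250000 nM
compound 2 `CCOC(=O)CNC(=O)NC1=CS(=O)(=O)O[C@@]12[C@@H](CO[Si](C)(C)C(C)(C)C)O[C@@H](n1cc(C)c(=O)n(C)c1=O)[C@@H]2O[Si](C)(C)C(C)(C)C`: 3780 nM
compound 3 `COC(=O)CCNC1=CS(=O)(=O)O[C@@]12[C@@H](CO[Si](C)(C)C(C)(C)C)O[C@@H](n1cc(C)c(=O)n(C)c1=O)[C@@H]2O[Si](C)(C)C(C)(C)C`: > 250000 nM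

For compound 3 the value is a limit of this assay, not a number. For compound 1 the value is likewise a limit. Compound 2 alone gives a number. Compound 1 therefore stands at the limit of > 250000 nM in this assay, at which 2 of the 3 values shown sit, and its distance from compound 2 can be read only as an at least 66-fold lower number from compound 1 to compound 2 (1.82 log units; beyond the scatter).

Compound 4 `COC(=O)NC1=CS(=O)(=O)O[C@@]12[C@@H](CO[Si](C)(C)C(C)(C)C)O[C@@H](n1cc(C)c(=O)n(C)c1=O)[C@@H]2O[Si](C)(C)C(C)(C)C` is the unmeasured member; it differs from compound 1 by methoxycarbonyl in place of 2-(benzyloxycarbonyl)ethyl on an amine nitrogen. Among the measured compounds shown here, the steps that bear on it are an at least 66-fold lower number from compound 1 to compound 2 (1.82 log units; beyond the scatter) and an at least 66-fold higher number from compound 2 to compound 3 (1.82 log units; beyond the scatter): where a carbamoyl group sits on the amine nitrogen, as in compound 2, the number was far lower; where a 2-(benzyloxycarbonyl)ethyl or 2-(methoxycarbonyl)ethyl chain sits there, as in compound 1 and compound 3, only the limit was reached. a step that the two limits leave unreadable from compound 1 to compound 3 cannot be read. Methoxycarbonyl, like carbamoyl, is a carbonyl group bound to the amine nitrogen, so for compound 4 a step of an at least 12-fold lower number from compound 1 to compound 4 (1.09 log units; beyond the scatter) is expected, with an at least 66-fold lower number from compound 1 to compound 2 (1.82 log units; beyond the scatter) as the basis. For compound 4 the estimate is 20000 nM, within 3000 nM to 250000 nM, with a real chance that only a limit is returned.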

Compound 4, half-maximal cytotoxic concentration: 29900 nM
The estimate for compound 4 lay 1.5-fold (0.17 log units) below the measured number; the range from low to high includes it.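

In this assay, compound 1 and compound 3 remain at the limit of the assay: the limit of > 250000 nM in this assay, at which 2 of the 4 values shown sit. Methoxycarbonyl on the amine nitrogen leaves that limit, with an at least 8.3-fold lower number from compound 1 to compound 4 (0.92 log units; beyond the scatter) and an at least 8.3-fold lower number from compound 3 to compound 4 (0.92 log units; beyond the scatter), so a carbonyl group on this nitrogen gives a readable number in compound 4 as in compound 2, without the ((ethoxycarbonyl)methyl)amino part. That part still changes the number, since methoxy in its place on the carbonyl carbon gives a 7.9-fold higher number from compound 2 to compound 4 (0.90 log units; beyond the scatter).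

The step between compound 1 and compound 3 cannot be read, so the two chains cannot be ranked against each other. Open, on these data alone, is how an acetyl group on the amine nitrogen, or a carboxylic acid in place of the ethyl ester of compound 2, would read in this assay.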